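This account rests on a few compounds, and the source may have more. Where it says the series, first, only, none or still open, it means among the compounds named here.

Going by the values given here, in an in vitro functional assay on cells for agonist activity at Bombesin receptor subtype-3 (Mus musculus), read by luminescence and calcium flux (on this read-out lower numbers stand for an effect already at smaller amounts and higher numbers for an effect only at larger amounts of compound), compound 3 `CCCCc1cnc(CCc2ccc(-c3ccccc3C(=O)O)cc2)[nH]1` gives 93 nM, the highest number among the three compounds measured so far. Compound 2 `COc1cccc(Cc2cnc(CCc3ccc(-c4ccccc4C(=O)O)cc3)[nH]2)c1` gives 79 nM, and the difference a 1.2-fold higher number from compound 2 to compound 3 (0.07 log units; within the scatter) lies within the usual scatter, so the two cannot be told apart. Compound 1 `Cc1ccccc1Cc1cnc(CCc2ccc(-c3ccccc3C(=O)O)cc2)[nH]1` gives 9.3 nM, and the step of a 10-fold higher number from compound 1 to compound 3 (1.00 log units; beyond the scatter) is beyond the scatter, as is the step of an 8.5-fold higher number from compound 1 to compound 2 (0.93 log units; beyond the scatter).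

Compound 4 `CC(C)(C)c1cnc(CCc2ccc(-c3ccccc3C(=O)O)cc2)[nH]1` has not yet been measured. It differs from compound 3 in one place: tert-butyl in place of butyl on an aromatic carbon. The two compounds contain the same atoms, arranged differently, and the change sits on an aromatic carbon of a five-membered aromatic ring with two nitrogens, next to the ring nitrogen.

Among the compounds with values here, none of the measured steps touches this place. All of them, from compound 1 to compound 2, from compound 1 to compound 3 and from compound 2 to compound 3, exchange the group on the saturated chain carbon bound to an aromatic carbon, and they say nothing about straightening or branching the chain itself. There is therefore no direct guide here, and the expected step of a 1.1-fold higher number from compound 3 to compound 4 (0.03 log units; within the scatter) is taken to stay within the scatter. The estimate for compound 4 in this assay is 100 nM, with a range from 30 nM to 350 nM.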

Compound 4, half-maximal effective concentration: 2750 nM
Estimate against measurement, compound 4: 28-fold (1.44 log units) below, outside the stated range (above it).
By their numbers in this assay, from the lowest: compound 1; then compounds 2 and 3 (each within the scatter of the next); then compound 4.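

In this assay, rearranging the same four carbons from butyl into tert-butyl gives a 30-fold higher number from compound 3 to compound 4 (1.47 log units; beyond the scatter), so in this pair the shape of the group on this aromatic carbon matters, even though the atom count is unchanged. The earlier compounds shown here could not show this, as they differed only in exchanging butyl, 3-methoxybenzyl and 2-methylbenzyl, and tert-butyl now stands well apart from both benzyl groups, with a 35-fold higher number from compound 2 to compound 4 (1.54 log units; beyond the scatter) and a 300-fold higher number from compound 1 to compound 4 (2.47 log units; beyond the scatter), the largest step in this set. Nothing measured here explains why this rearrangement has such a large effect on the number.

The four compounds leave open whether branched chains in general give a step of this size or whether it is particular to tert-butyl, a question that isopropyl and isobutyl at this same place would help to answer. From the compounds shown here alone, it also remains open how a longer chain such as hexyl, or a chain ending in an amine, would compare with butyl here.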